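A few compounds are considered here, and "the series" means these few. Any claim that something is new, unique, unknown or untested is made for them only; others in the source may bear on it.

Measured so far:
compound 1 `O=C(O)CCCCOc1cc(-c2ccccc2)cc(-c2ccccc2)n1`, 300 nM
compound 2 `CC(CCCCOc1cc(-c2ccccc2)cc(-c2ccccc2)n1)C(=O)O`, 30 nM

Within the data shown here, in an assay for binding affinity to leukotriene B4 receptor 1 (Homo sapiens) (a higher number here means a weaker inhibitor, a lower number a stronger inhibitor), compound 2 holds the lowest of the two numbers, with compound 1 as its only neighbour. Compound 3 `O=C(O)CCCCCCOc1cc(-c2ccccc2)cc(-c2ccccc2)n1` differs from compound 2 by 2-carboxyethyl in place of 1-carboxyethyl on a saturated chain carbon, four bonds along the chain from an oxygen on an aromatic ring. Among the measured compounds shown here, the one measured step, a 10-fold lower number from compound 1 to compound 2 (1.00 log units; beyond the scatter), concerns a branch on the chain rather than a longer straight chain, so it bears only loosely here; compound 3 is straight like compound 1 but longer. Compound 3 is therefore expected to land between the two, at an estimated 150 nM (range 40 nM to 600 nM), meaning an expected step of a 5.0-fold higher number from compound 2 to compound 3 (0.70 log units; beyond the scatter).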

Compound 3, half-maximal inhibitory concentration: 15 nM
Compound 3: middle estimate off by 10-fold (1.00 log units), on the high side; the measured number lies below the stated range.
By their numbers in this assay, from the lowest: compounds 3 and 2 (each within the scatter of the next); then compound 1.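

In this assay, exchanging 1-carboxyethyl for 2-carboxyethyl at this position makes no clear difference (a 2.0-fold lower number from compound 2 to compound 3 (0.30 log units; within the scatter)), so a low number here does not depend on the branch of compound 2. Exchanging carboxy for 2-carboxyethyl has a large effect (a 20-fold lower number from compound 1 to compound 3 (1.30 log units; beyond the scatter)), so an unbranched chain can also reach this range. Nothing measured here explains either step.

Still open, going by these compounds, is whether a longer chain, or a methyl branch on the chain of compound 3, would change the number. Also open, on these data alone, is whether an amide could replace the carboxylic acid.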